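The source may hold more compounds than are shown below. What is called first, only, known or untested is meant among the compounds shown, and "the series" means these compounds.

Compound 1 `Cc1cnnc(N2CCN(C(=O)Nc3ccc(C(C)C)cc3)CC2)c1` is the only one of the three measured compounds that returns a number in an assay on HEK293 cells for inhibition of transient receptor potential cation channel subfamily V member 1 (Homo sapiens), read by FLIPR (on this read-out lower numbers stand for stronger inhibition and higher numbers for weaker inhibition), where compound 1 gives 5020 nM. Compound 2 `CC(C)(C)c1ccc(NC(=O)N2CCN(c3nncc4ccccc34)CC2)cc1` reaches only the limit of this assay, reported for compound 2 as > 10000 nM. Compound 3 `CC(C)c1ccc(NC(=O)N2CCN(c3nncc4ccccc34)CC2)cc1` differs from compound 2 by hydrogen in place of methyl on a saturated chain carbon bound to an aromatic carbon and two saturated chain carbons, and compound 3 likewise reaches only the limit of this assay, recorded as > 10000 nM. The step that the two limits leave unreadable from compound 2 to compound 3 therefore has no readable size, because both values sit at the limit of > 10000 nM in this assay, at which 2 of the 3 values shown sit. Compound 3 thus stands as a limit only, alongside compound 2, with no number to place it.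

Compound 4 `O=C(Nc1ccc(C(F)(F)F)cc1)N1CCN(c2nncc3ccccc23)CC1` carries trifluoromethyl in place of isopropyl on an aromatic carbon, that is trifluoromethyl in place of isopropyl on an aromatic carbon of a six-membered aromatic ring of carbon only. Going by the values given here, the only measured step on the core of compound 3, a step that the two limits leave unreadable from compound 2 to compound 3, gives no direction, and both compounds sharing that core sit at the limit. Compound 4 is therefore estimated at 12000 nM, with the likely range running from 4000 nM to 35000 nM. The step this estimate implies is expected to be a step that the limit leaves unreadable from compound 3 to compound 4, no change beyond the scatter, and most likely another limit.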

Compound 4, half-maximal inhibitory concentration: > 10000 nM
Compound 4: only a limit was reported; the forecaster's own chance of this, stated with the estimate: 70%; the middle value lies beyond the limit too.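

In this assay compound 4 returns only a limit, > 10000 nM. Compound 2 and compound 3 are also held at a limit, so no step among these three compounds can be read: the limit of > 10000 nM in this assay, at which 3 of the 4 values shown sit.

On these data alone, what remains open is whether tert-butyl, isopropyl and trifluoromethyl differ at all on the shared core, since none of the three compounds has a number.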